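This account rests on a few compounds, and the source may have more. Where it says the series, first, only, none or still open, it means among the compounds named here.

Series on record:
compound 1, `COc1cc(-c2nn(-c3cccc(NC(=O)c4cccc(C(F)(F)F)c4)c3)cc2-c2ccncc2)ccc1Cl`, in a functional assay on SF-295 cells (Homo sapiens) for inhibition, read by sulforhodamine B assay, with a stated time of 48 h; a lower number here means a stronger inhibitor, a higher number a weaker inhibitor: 1020 nM
compound 2, `COc1cc(-c2nn(-c3cccc(NC(=O)Nc4ccc(Cl)c(C(F)(F)F)c4)c3)cc2-c2ccncc2)ccc1Cl`, in this assay: 840 nM

Going by the values given here, compound 2 has the lowest number of the two; its only neighbour is compound 1, and a 1.2-fold lower number from compound 1 to compound 2 (0.08 log units; within the scatter). Compound 3, `COc1cc(-c2nn(-c3cccc(NC(=O)c4ccccc4)c3)cc2-c2ccncc2)ccc1Cl`, is not yet measured; the change is phenyl in place of (4-chloro-3-(trifluoromethyl)phenyl)amino on a carbonyl carbon. Among the compounds with values here, the one step that bears on it, a 1.2-fold lower number from compound 1 to compound 2 (0.08 log units; within the scatter), also reworked this carbonyl substituent and stayed within the scatter, so for compound 3 no step beyond the scatter is expected in this assay, with a 1.4-fold higher number from compound 2 to compound 3 (0.15 log units; within the scatter) as the estimated shift. Compound 3 is thus expected at 1200 nM, range 600 nM to 2600 nM.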

Compound 3, half-maximal inhibitory concentration: 340 nM
Estimate against measurement, compound 3: 3.5-fold (0.55 log units) above; the whole stated range lies above it.
By their numbers in this assay, from the lowest: compound 3; then compounds 2 and 1 (each within the scatter of the next).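

Phenyl on the carbonyl carbon separates from the earlier compounds in this assay (a 2.5-fold lower number from compound 2 to compound 3 (0.39 log units; beyond the scatter)), although the only earlier change here stayed within the scatter. Hydrogen in place of trifluoromethyl on an aromatic carbon is, as a single change, also beyond the scatter (a 3.0-fold lower number from compound 1 to compound 3 (0.48 log units; beyond the scatter)). Nothing on hand explains either step. The step from compound 2 to compound 3 removes the amino link and both ring substituents together, so their shares remain unresolved. Going by these compounds, whether a methoxy or dimethylamino group on that phenyl would hold the lower number also remains open.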